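The compounds below may be only part of what the source reports. "The series", "measured", "known", "first", "only" and "open" are said of these compounds alone.

Working notes on the series. Compound 3 `O=C(/C(=C\c1c(O)cc(O)cc1O)S(=O)(=O)c1ccccc1Br)c1ccc(Cl)cc1` is compound 1 `O=C(/C(=C\c1c(O)cc(O)cc1O)S(=O)(=O)c1ccccc1Br)c1ccc(Br)cc1` with chloro in place of bromo on an aromatic carbon. In a functional assay on DU-145 cells (Homo sapiens) for inhibition, read by trypan blue exclusion, with a stated time of 96 h (a lower number here means a stronger inhibitor of growth, a higher number a weaker inhibitor of growth), compound 3 gives 50000 nM, and compound 1 gives 50000 nM. For the measured compounds named here, the only step measured within the set, no change at the digits printed from compound 1 to compound 3 (within the scatter), thus runs flat. Compound 2 `O=C(/C(=C\c1ccc(O)c([N+](=O)[O-])c1)SCc1ccccc1Cl)c1ccc(Cl)cc1`, of a different build, gives 10000 nM in this assay; on these three numbers compound 3 stands level with compound 1 at the top, with compound 2 the lone lower value and that gap beyond the scatter.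

Compound 4 `O=C(/C(=C\c1c(O)cc(O)cc1O)S(=O)(=O)c1ccc(Br)cc1)c1ccc(Cl)cc1` differs from compound 3 by 4-bromophenyl in place of 2-bromophenyl on a sulfonyl sulfur. Going by the values given here, no measured step moves the bromine on the ring attached to the sulfonyl sulfur; the one known step concerns the other aromatic ring and stays within the scatter, so nothing in hand points either way. The expectation for compound 4 in this assay is therefore no change at the digits printed from compound 3 to compound 4 (within the scatter), nothing beyond the scatter. Compound 4 is estimated at 50000 nM, within a range of 20000 nM to 100000 nM.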

Compound 4, concentration for 50% growth inhibition: > 100000 nM
Compound 4: a limit, no number; the forecaster's own chance of this, stated with the estimate: 35%; at least 2.0-fold (0.30 log units) between middle value and limit.
By their numbers in this assay, from the lowest: compound 2; then compounds 1 and 3 (each within the scatter of the next). At a limit, above all of these: compound 4.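

In this assay compound 4 gives > 100000 nM, which is a limit of the assay and not a number. For the compounds shown here, the earlier compounds held no step at the ring on the sulfonyl sulfur, and the one step they did hold, no change at the digits printed from compound 1 to compound 3 (within the scatter), concerned the other aromatic ring; moving to 4-bromophenyl in place of 2-bromophenyl gives an at least 2.0-fold higher number from compound 3 to compound 4 (0.30 log units; that floor lies within the scatter), so this position may respond to where the bromine sits, though the floor of that step does not show this on its own. The reading therefore rests on a limit and not on a measured size: the limit of > 100000 nM in this assay, at which 1 of the 4 values shown sits.

Still open, as far as these compounds go, is whether a number for compound 4 would lie beyond the scatter from compound 3. Also open, from the compounds shown here alone, is how this assay would respond to 3-bromophenyl, or to an amine or a carboxylic acid in place of the bromine on this ring.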